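From 4-fluorophenyl to 2-chlorophenyl in compound 3

The compounds below may be only part of what the source reports. "The series", "measured", "known", "first", "only" and "open" are said of these compounds alone.

For the measured compounds named here, in an ADME assay on HUVEC cells (Homo sapiens) for inhibition, read by CCK-8 assay, with a stated time of 24 h, in the presence of a further agent that is not named here (on this read-out higher numbers stand for weaker inhibition and lower numbers for stronger inhibition), compound 2 `O=C1Nc2ccccc2/C1=C/c1ccc(-c2cn(-c3ccc(F)cc3)nn2)cc1` gives 14700 nM, the only actual number so far. Compound 1 `O=C1Nc2ccccc2/C1=C/c1ccc(-c2cn(-c3cccc(F)c3)nn2)cc1` reads > 20000 nM, which is a limit of the assay and not a number. Compound 3 `O=C1Nc2ccccc2/C1=C/c1ccc(-c2cn(-c3ccccc3Cl)nn2)cc1` has 2-chlorophenyl in place of 4-fluorophenyl on an aromatic nitrogen. Going by the values given here, the one measured step at this place, 4-fluorophenyl in place of 3-fluorophenyl, is an at least 1.3-fold lower number from compound 1 to compound 2 (0.13 log units; that floor lies within the scatter), so no step beyond the scatter is expected in this assay. The expected change is a 1.1-fold higher number from compound 2 to compound 3 (0.04 log units; within the scatter). Compound 3 is estimated at 16000 nM, with an expected range of 8000 nM to 30000 nM.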

Compound 3, half-maximal inhibitory concentration: > 20000 nM
Compound 3 ended at the assay's limit; the forecaster's own chance of this, stated with the estimate: 45%; at least 1.2-fold (0.09 log units) between middle value and limit.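

In this assay, 2-chlorophenyl in place of 4-fluorophenyl on the aromatic nitrogen gives an at least 1.3-fold higher number from compound 2 to compound 3 (0.13 log units; that floor lies within the scatter), so only a floor for this change is known. The reading for compound 3 is a limit of the assay, not a number. The step between compound 1 and compound 3 cannot be read, and most of this small set now sits at one ceiling: the limit of > 20000 nM in this assay, at which 2 of the 3 values shown sit.

Still open, going by these compounds, is whether a phenyl ring carrying an amine or a carboxylic acid on this nitrogen would give a clearly lower number. The reference for that question is compound 2, which gives 14700 nM.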